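The source may hold more compounds than are shown below. What is called first, only, known or untested is meant among the compounds shown, and "the series" means these compounds.

Measured so far:
compound 1, `CN(C)C(=O)c1cnc(C(=O)CCc2ccc(Oc3ccccc3)cc2)o1`, 5.4 nM
compound 2, `COC(=O)c1cnc(C(=O)CCc2ccc(Oc3ccccc3)cc2)o1`, 1.7 nM
compound 3, `N#Cc1cnc(C(=O)CCc2ccc(Oc3ccccc3)cc2)o1`, 0.8 nM

In an assay for inhibition of Fatty-acid amide hydrolase 1 (Rattus norvegicus) (a lower number here means a stronger inhibitor, a higher number a weaker inhibitor), compound 3 holds the lowest number of the three; the step of a 2.1-fold lower number from compound 2 to compound 3 (0.33 log units; beyond the scatter) and the step of a 6.8-fold lower number from compound 1 to compound 3 (0.83 log units; beyond the scatter) both lie beyond the scatter, so compound 3 is the strongest inhibitor measured here. Compound 4, `O=C(CCc1ccc(Oc2ccccc2)cc1)c1ncc(I)o1`, differs from compound 3 by iodo in place of cyano on an aromatic carbon. Within the data shown here, no measured step tests iodo; the three known steps all exchange groups at this same place on the core, and each exchange moved the number by a modest amount, so a step of at most modest size is expected for a 1.9-fold higher number from compound 3 to compound 4 (0.27 log units; within the scatter), its direction uncertain. Compound 4 is estimated at 1.5 nM, range 0.5 nM to 5 nM.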

Compound 4, inhibition constant: 10 nM
For compound 4 the middle estimate is 6.7-fold (0.82 log units) below the measured one, outside the stated range (above it).
By their numbers in this assay, from the lowest: compound 3; then compound 2; then compounds 1 and 4 (each within the scatter of the next).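

In this assay, iodo on the aromatic carbon next to the ring oxygen gives a weaker inhibitor than either cyano or methoxycarbonyl: a 13-fold higher number from compound 3 to compound 4 (1.10 log units; beyond the scatter) is a large step, and a 5.9-fold higher number from compound 2 to compound 4 (0.77 log units; beyond the scatter) also lies beyond the scatter. Iodo and dimethylcarbamoyl, however, are not separated at this position, with a 1.9-fold higher number from compound 1 to compound 4 (0.27 log units; within the scatter). The data shown offer no explanation for these differences.

Open, on these data alone, is how an amine or a carboxylic acid at this position would compare with compound 3, and whether a chlorine atom would track iodo.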